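A Methoxy Step Repeated on a Second Core

This account rests on a few compounds, and the source may have more. Where it says the series, first, only, none or still open, it means among the compounds named here.

Compound 1 `N=C(N)c1cccc(-c2cc3cc(C(=N)N)ccc3o2)c1` gives 21200 nM in an ADME assay on L6 cells (Rattus norvegicus) for cytotoxicity; a higher number here means a weaker inhibitor, a lower number a stronger inhibitor. Compound 3 `COc1ccc(C(=N)N)cc1-c1cc2cc(C(=N)N)ccc2o1` arises from it by methoxy in place of hydrogen on an aromatic carbon and gives 179000 nM in this assay, a step of an 8.4-fold higher number from compound 1 to compound 3 (0.93 log units; beyond the scatter). Compound 2 `CC(C)NC(=N)c1cccc(-c2cc3cc(C(=N)NC(C)C)ccc3o2)c1` carries another core, and the difference between the two cores is not broken down here. In this assay compound 2 gives only a limit, > 199000 nM. Compound 4 `COc1ccc(C(=N)NC(C)C)cc1-c1cc2cc(C(=N)NC(C)C)ccc2o1` differs from compound 2 by methoxy in place of hydrogen on an aromatic carbon, the same kind of change as before, though here the place is para to a group of 6 heavy atoms rather than a group of 3 heavy atoms. Because the limit of > 199000 nM in this assay, at which 1 of the 3 values shown sits, already holds compound 2, another limit is expected for compound 4. Beside the earlier 8.4-fold higher number from compound 1 to compound 3 (0.93 log units; beyond the scatter), the step from compound 2 to compound 4 is expected to be a step that the limit leaves unreadable from compound 2 to compound 4. Compound 4 is estimated at 600000 nM in this assay, between 150000 nM and 2500000 nM.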

Compound 4, half-maximal inhibitory concentration: > 179000 nM
Compound 4 gave a limit, no number; the forecaster's own chance of this, stated with the estimate: 85%; the middle value is on the limit's open side.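

In this assay, going by these compounds alone, compound 2 and compound 4 both give only limits, so no step between them can be read. The compounds shown leave open whether methoxy on the core of compound 2 matches the earlier step, an 8.4-fold higher number from compound 1 to compound 3 (0.93 log units; beyond the scatter).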